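Chain-extended piperazine analogue, compound 4, before measurement

This account rests on a few compounds, and the source may have more. Where it says the series, first, only, none or still open, it means among the compounds named here.

Compound 3 `CN1CCN(CCCn2c3c(c4ccccc42)C(=O)c2c[n+]([O-])c4ccccc4c2C3=O)CC1` gives 220 nM in a functional assay on MCF7 cells (Homo sapiens) for cytotoxicity, read by MTT assay, with a stated time of 72 h; a lower number here means a stronger inhibitor, a higher number a weaker inhibitor. Within the data shown here, it stands second highest of the three numbers so far. Its nearest neighbour is compound 2 `O=C1c2c[n+]([O-])c3ccccc3c2C(=O)c2c1c1ccccc1n2CCN1CCCC1`, which gives 320 nM in this assay; its furthest is compound 1 `O=C1c2c[n+]([O-])c3ccccc3c2C(=O)c2c1c1ccccc1n2CCCCN1CCCCC1`, which gives 150 nM in this assay. Both steps onto compound 3, a 1.5-fold lower number from compound 2 to compound 3 (0.16 log units; within the scatter) and a 1.5-fold higher number from compound 1 to compound 3 (0.17 log units; within the scatter), lie within the scatter, so the three cannot be ordered against one another with confidence. Among the measured compounds shown here, the only step beyond the scatter is a 2.1-fold higher number from compound 1 to compound 2 (0.33 log units; beyond the scatter), in which the group with fewer heavy atoms carried the higher number.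

Compound 4 `CCCN1CCN(CCCCn2c3c(c4ccccc42)C(=O)c2c[n+]([O-])c4ccccc4c2C3=O)CC1` differs from compound 3 by (4-propylpiperazin-1-yl)methyl in place of 4-methylpiperazin-1-yl on a saturated chain carbon, three bonds along the chain from an aromatic nitrogen. For the measured compounds named here, the steps that bear on this change are a 1.5-fold higher number from compound 1 to compound 3 (0.17 log units; within the scatter) and a 1.5-fold lower number from compound 2 to compound 3 (0.16 log units; within the scatter), both within the scatter, which show that exchanging the group at this place has so far moved the number little, and a 2.1-fold higher number from compound 1 to compound 2 (0.33 log units; beyond the scatter), which points toward a lower number when the group at this place grows. The expected step is therefore a 1.2-fold lower number from compound 3 to compound 4 (0.09 log units; within the scatter), a small move toward a lower number, not clearly beyond the scatter. Compound 4 is estimated at 180 nM, with a range of 80 nM to 400 nM.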

Compound 4, half-maximal inhibitory concentration: 1280 nM
Compound 4: middle estimate off by 7.1-fold (0.85 log units), on the low side; measured number above the stated range.
By their numbers in this assay, from the lowest: compounds 1, 3 and 2 (each within the scatter of the next, the first and the last beyond it); then compound 4.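

In this assay, among these compounds, a 5.8-fold higher number from compound 3 to compound 4 (0.76 log units; beyond the scatter) is a larger move than any among the earlier compounds, so this position is not as forgiving as their small steps suggested. The direction also reverses: the group with more heavy atoms now carries the higher number, and compound 4 goes against the trend suggested by compound 1 and compound 2. With a 4.0-fold higher number from compound 2 to compound 4 (0.60 log units; beyond the scatter) and an 8.5-fold higher number from compound 1 to compound 4 (0.93 log units; beyond the scatter), compound 4 stands apart from all three, and the last step shows that 4-propylpiperazin-1-yl in place of piperidin-1-yl at the four-bond place is enough for a large rise.

The step from compound 3 combines a longer chain with a propyl group in place of methyl, and a 4-methylpiperazin-1-yl on the chain of compound 4 would separate the two. Nothing available explains the rise.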